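Styryl to Propenyl on the Oxazole of Compound 2

The source may report more compounds than this note shows. Statements on the series, on what has been measured and on what is new or still open speak of the compounds shown alone.

Measured compounds:
compound 1, `CC(=O)O[C@H]1C=CC(=O)O[C@H]1[C@H]1OC(=O)O[C@@H]1c1ccccc1`, > 40000 nM
compound 2, `CC(=O)O[C@H]1C=CC(=O)O[C@@H]1c1nc(/C=C/c2ccccc2)oc1-c1ccccc1`, 7360 nM
compound 3, `CC(=O)O[C@H]1C=CC(=O)O[C@H]1[C@H]1OC(C)(C)O[C@@H]1c1ccccc1`, > 40000 nM

For the measured compounds named here, in a functional assay on SK-BR-3 cells (Homo sapiens) for cytotoxicity, read by MTT assay, with a stated time of 48 h (on this read-out lower numbers stand for stronger inhibition and higher numbers for weaker inhibition), compound 2 gives 7360 nM, the only number among the three. Compound 1 reaches only a limit, > 40000 nM. Compound 3 also stops at a limit, > 40000 nM, so that (the limit of > 40000 nM in this assay, at which 2 of the 3 values shown sit). Compound 4, `C/C=C\c1nc([C@H]2OC(=O)C=C[C@@H]2OC(C)=O)c(-c2ccccc2)o1`, is not yet measured. Its difference from compound 2 is prop-1-en-1-yl in place of 2-phenylethenyl on an aromatic carbon, in words prop-1-en-1-yl in place of 2-phenylethenyl on an aromatic carbon. No step between measured compounds is given, so nothing shown fixes its size. He expects a modest loss in this assay, beyond the scatter, since the group entering is smaller than the one leaving. For compound 4 he estimates 15000 nM, within 5000 nM to 40000 nM, a step of a 2.0-fold higher number from compound 2 to compound 4 (0.31 log units; beyond the scatter).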

Compound 4, half-maximal inhibitory concentration: > 40000 nM
Compound 4 ended at the assay's limit (the forecaster's own chance of this, stated with the estimate: 25%); at least 2.6-fold (0.42 log units) between middle value and limit.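

For the compounds shown here, replacing 2-phenylethenyl with prop-1-en-1-yl on this aromatic carbon gives the first step that can be read at this position, an at least 5.4-fold higher number from compound 2 to compound 4 (0.73 log units; beyond the scatter) in this assay. The double bond outside aromatic rings stays, so the step goes with losing the six-membered aromatic ring of carbon only, and the value for compound 4 is a limit. Compound 2 alone now stays off that limit: the limit of > 40000 nM in this assay, at which 3 of the 4 values shown sit.

From the compounds shown here alone, the true size of the step remains open. So does whether a longer chain or an amine on this aromatic carbon would give a number in this assay.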